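A few compounds are considered here, and "the series" means these few. Any claim that something is new, unique, unknown or untested is made for them only; others in the source may bear on it.

Working notes on the series.

Compound 1 `ClCc1ccc(Cn2cnc3c(Cl)ncnc32)cc1` carries the shared core with a chloromethyl-bearing benzyl group; in a functional assay on T47D cells (Homo sapiens) for cytotoxicity, read by sulforhodamine B assay, with a stated time of 48 h (a higher number here means a weaker inhibitor of growth, a lower number a stronger inhibitor of growth), compound 1 gives "not determined" (no result reported), so it contributes no number. Going by the values given here, compound 2 `ClCc1ccccc1Cn1cnc2c(Cl)nc(Cl)nc21` is the only compound with a measured value: in this assay compound 2 gives 5490 nM, which is therefore the single reference point of the set, with nothing to compare it against within this assay.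

Compound 3 `ClCc1ccccc1Cn1cnc2c(Cl)ncnc21` differs from compound 2 in one place: hydrogen in place of chloro on an aromatic carbon. Among the compounds with values here, no pair of measured compounds shows this kind of change, so the size of the resulting step has no direct precedent here. Removing one of the two chloro groups from the core is a small structural change at a single position, but whether growth inhibition tracks with that chloro cannot be read from compound 2 alone. A modest loss of potency for compound 3 relative to compound 2 is expected, with the step of a 1.6-fold higher number from compound 2 to compound 3 (0.21 log units; within the scatter) assumed to lie close to, or only slightly beyond, the usual scatter. On that basis compound 3 is estimated at 9000 nM in this assay, within a range from 3000 nM to 27000 nM.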

Compound 3, concentration for total growth inhibition: 61700 nM
For compound 3 the middle estimate is 6.9-fold (0.84 log units) below the measured one; measured number outside the range, above it.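

In this assay hydrogen in place of chloro on the aromatic carbon between two ring nitrogen atoms gives an 11-fold higher number from compound 2 to compound 3 (1.05 log units; beyond the scatter) and thus a large step, the first step available in the series. Compound 2 alone offered only a reference point, whereas this pair shows that growth inhibition in these two compounds is sensitive to the group on this one carbon, with the chloro-bearing compound 2 the stronger inhibitor of growth and the loss of a single heavy atom enough to move the number well beyond the scatter. No measurement shown here bears on the reason for the size of this step.

Only chloro and hydrogen are shown on this carbon, so it remains open whether an amine, a methoxy group or a fluoro group would keep the growth inhibition of compound 2 or fall nearer to compound 3. As far as these compounds go, it also remains open whether the same change gives a step of similar size with the chloromethyl-bearing benzyl group of compound 1, or with the remaining chloro group replaced.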